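Replacing a Hydroxyphenyl Group with Pyrimidinyl at the Thioether

The source may hold more compounds than are shown below. What is called first, only, known or untested is meant among the compounds shown, and "the series" means these compounds.

Compound 1 `Cn1ncc2c(=O)n(-c3ccccc3)c(SC(C)(C)c3ccccc3)nc21`: 2200 nM
Compound 2 `CC(Sc1nc2c(cnn2C)c(=O)n1-c1ccccc1)c1cccc(F)c1`: 110 nM
Compound 3 `CC(Sc1nc2c(cnn2C)c(=O)n1-c1ccccc1)c1cccc(O)c1`: 100 nM

In an assay on isolated protein for inhibition of retinal dehydrogenase 2 (Homo sapiens) (a lower number here means a stronger inhibitor, a higher number a weaker inhibitor), compound 3 gives 100 nM, the lowest of the three numbers; compound 2 sits within the scatter of it, while compound 1 lies far higher. Compound 4 `CC(Sc1nc2c(cnn2C)c(=O)n1-c1ccccc1)c1cncnc1` differs from compound 3 in one place: pyrimidin-5-yl in place of 3-hydroxyphenyl on a saturated chain carbon bound to a saturated chain carbon and a sulfur. Within the data shown here, no measured step swaps one ring for another. The steps of a 20-fold lower number from compound 1 to compound 2 (1.30 log units; beyond the scatter) and a 22-fold lower number from compound 1 to compound 3 (1.34 log units; beyond the scatter) concern the chain on the sulfur, not the ring, and the step of a 1.1-fold lower number from compound 2 to compound 3 (0.04 log units; within the scatter) shows that hydroxy against fluoro on the ring changes little. A whole-ring exchange is less certain, so a modest rise in the number is expected, a 2.5-fold higher number from compound 3 to compound 4 (0.40 log units; beyond the scatter). Compound 4 is therefore estimated at 250 nM, ranging from 80 nM to 800 nM.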

Compound 4, half-maximal inhibitory concentration: 380 nM
The estimate for compound 4 lay 1.5-fold (0.18 log units) below the measured number; the range from low to high includes it.
By their numbers in this assay, from the lowest: compounds 3 and 2 (each within the scatter of the next); then compound 4; then compound 1.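

Exchanging the whole ring at this position moves the number in this assay further than hydroxy against fluoro did, with a 3.8-fold higher number from compound 3 to compound 4 (0.58 log units; beyond the scatter) and a 3.5-fold higher number from compound 2 to compound 4 (0.54 log units; beyond the scatter) when pyrimidin-5-yl replaces either substituted phenyl ring. The ring here therefore matters, yet the change does not erase the advantage over the group on sulfur in compound 1, with a 5.8-fold lower number from compound 1 to compound 4 (0.76 log units; beyond the scatter) still standing. No evidence is available to explain the cost of this ring exchange.

Going by these compounds, whether pyridin-3-yl would sit with the phenyl compounds or with compound 4 remains open, as does the effect of an amine on the phenyl ring.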